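Inversion of all stereocentres in the biphenyl analogue

The source may hold more compounds than are shown below. What is called first, only, known or untested is meant among the compounds shown, and "the series" means these compounds.

Among the measured compounds shown here, compound 2, `O[C@@H]1[C@@H](O)CN[C@H]1c1ccc(-c2ccccc2)cc1`, gives 0% in an assay on isolated protein for inhibition of alpha-mannosidase (Canavalia ensiformis), read by spectrophotometry, tested at 1000 uM (a higher number here means more inhibition at the concentration tested (going by the name of the read-out), a lower number less inhibition), the lowest of the two numbers measured so far. Compound 1, `O[C@H]1[C@H](O)CN[C@@H]1c1ccccc1`, gives 8.3% in this assay, a difference that lies within the scatter. Compound 3, `O[C@H]1[C@H](O)CN[C@@H]1c1ccc(-c2ccccc2)cc1`, has not been measured; its difference from compound 2 is the two compounds have the same atoms and bonds and differ only in configuration as drawn: 3 of 3 stereo elements differ (all stereocentres are inverted: mirror images); a stereocentre at a saturated ring carbon is drawn S in compound 2 and R in compound 3; a stereocentre at a saturated ring carbon is drawn S in compound 2 and R in compound 3; a stereocentre at a saturated ring carbon is drawn S in compound 2 and R in compound 3. With both measured values sitting near zero, a step of a number 4 percentage points higher from compound 2 to compound 3 (within the scatter) of no size beyond the scatter is expected in either direction. Compound 3 is estimated at 4% in this assay, with a range of 0% to 15%.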

Compound 3, a percentage reported as inhibition, at one concentration (the size of the read-out at that concentration, not a potency): 0%
For compound 3 the middle estimate is 4 percentage points above the measured one, within the range that was stated.
By their numbers in this assay, from the lowest: compounds 2, 3 and 1 (each within the scatter of the next).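

In this assay, inversion of all stereocentres in the biphenyl analogue gives no change at the digits printed from compound 2 to compound 3 (within the scatter), so at the concentration tested this mirror-image pair is not separated: the fact that compounds 2 and 3 differ only in the configuration as drawn. With the configuration as drawn held constant, phenyl in place of hydrogen on an aromatic carbon gives a number 8.3 percentage points lower from compound 1 to compound 3 (within the scatter) and so shows no effect beyond the scatter.

With all three compounds this close to zero, these data cannot show whether configuration matters in an analogue with a higher number in this assay. Going by these compounds, whether an amine or a carboxylic acid in place of that phenyl would raise inhibition in this assay remains open.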